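The compounds below may be only part of what the source reports. "The series", "measured", "known", "first", "only" and "open" are said of these compounds alone.

Measured compounds:
Compound 1, `COc1ccc(/C(Cl)=C/C=C(\C#N)C(=O)c2c[nH]c3ccc(Br)cc23)cc1` — 15.6%
Compound 2, `N#C/C(=C\C=C(/Cl)c1ccc(Br)cc1)C(=O)c1c[nH]c2ccccc12` — 18.4%

Both compounds were tested in a functional assay for inhibition, with a stated time of 30 min, tested at 1 mM; on this read-out higher numbers stand for more inhibition at the one concentration tested (going by the name of the read-out) and lower numbers for less inhibition. Of the two numbers, compound 2 stands highest, but its nearest neighbour, compound 1, lies within the usual scatter of this kind of measurement, so the two results cannot be told apart. Going by the values given here, compound 1 and compound 2 differ from each other in more than one place, so no single structural step connects them, and their two values show only that they sit close together.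

Compound 3, `COc1ccc(/C(Cl)=C/C=C(\C#N)C(=O)c2c[nH]c3ccccc23)cc1`, has not yet been measured. It differs from compound 2 in one place: methoxy in place of bromo on an aromatic carbon. Among the compounds with values here, no pair of measured compounds shows what this change does on its own, so the expectation rests only on the two values above, which lie close to each other. The step of a number 1.4 percentage points lower from compound 2 to compound 3 (within the scatter) is expected to be small, not beyond the scatter, in either direction. Compound 3 is therefore expected to give about 17% in this assay, with a range from 5% to 30%.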

Compound 3, a percentage reported as inhibition, at one concentration (the size of the read-out at that concentration, not a potency): 23.4%
The estimate for compound 3 lay 6.4 percentage points below the measured number; low and high end bracket the measured number.
By their numbers in this assay, from the lowest: compounds 1, 2 and 3 (each within the scatter of the next).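

In this assay the change from 4-bromophenyl to 4-methoxyphenyl gives a number 5 percentage points higher from compound 2 to compound 3 (within the scatter), so at this position on the aromatic ring a bromo group and a methoxy group cannot be told apart, even though the methoxy group brings a hydrogen-bond acceptor that the bromo group lacks. Going by these compounds alone, compound 3 also gives the first pair that isolates a change on the other aromatic ring: hydrogen in place of bromo gives a number 7.8 percentage points higher from compound 1 to compound 3 (within the scatter), so that swap cannot be told apart from the scatter either. No other measurement is available to explain either result.

These three compounds span only bromo, methoxy and hydrogen at the two positions, so they leave open whether a quite different group, such as an amine or a carboxylic acid on the phenyl ring, would move the number beyond the scatter. Each compound also has a reading at only one concentration, which leaves open how the compounds would compare across a range of concentrations.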